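Amino in place of hydroxy: cytotoxicity outlook for compound 4

A few compounds are considered here, and "the series" means these few. Any claim that something is new, unique, unknown or untested is made for them only; others in the source may bear on it.

Compound 3 `O=c1c(C2=CS(=O)(=O)c3cc(O)ccc3N2)c(O)c2cc(F)ccc2n1Cc1ccc(F)cc1` carries a hydroxy on an aromatic carbon of the shared core. In an ADME assay on 2209-23 cells (Homo sapiens) for cytotoxicity, read by WST assay (a lower number here means that less compound is tolerated, a higher number that more compound is tolerated), compound 3 gives > 50000 nM, which is a limit of the assay and not a number. Compound 1 `O=c1c(C2=CS(=O)(=O)c3cc(F)ccc3N2)c(O)c2cc(F)ccc2n1Cc1ccc(F)cc1` carries a fluoro on an aromatic carbon instead. In this assay compound 1 gives > 50000 nM, again a limit rather than a number. Compound 2 `N#Cc1ccc2c(c1)S(=O)(=O)C=C(c1c(O)c3cc(F)ccc3n(Cc3ccc(F)cc3)c1=O)N2` carries a cyano on an aromatic carbon. In this assay compound 2 gives > 50000 nM, also a limit. The three steps that join these compounds, a step that the two limits leave unreadable from compound 1 to compound 2, a step that the two limits leave unreadable from compound 1 to compound 3 and a step that the two limits leave unreadable from compound 2 to compound 3, thus cannot be read for size or direction; what is known is the limit of > 50000 nM in this assay, at which 3 of the 3 values shown sit.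

Compound 4 `Nc1ccc2c(c1)S(=O)(=O)C=C(c1c(O)c3cc(F)ccc3n(Cc3ccc(F)cc3)c1=O)N2` differs from compound 3 by amino in place of hydroxy on an aromatic carbon. For the measured compounds named here, no measured step touches an amino, and none of the steps that exchange the substituent on this aromatic carbon is readable, so the measured compounds supply no step size to carry over. With every value in the series resting at the limit, compound 4 is expected to sit there as well, an estimated step that the limit leaves unreadable from compound 3 to compound 4. The estimate for compound 4 is 60000 nM, with a range from 20000 nM to 200000 nM.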

Compound 4, half-maximal cytotoxic concentration: > 50000 nM
Compound 4: no number, only a limit; the forecaster's own chance of this, stated with the estimate: 80%; the middle value lies beyond the limit too.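

In this assay compound 4 gives > 50000 nM, a limit of the assay and not a number. The steps joining compound 4 to compound 1, compound 2 and compound 3 therefore cannot be read for size or direction: the limit of > 50000 nM in this assay, at which 4 of the 4 values shown sit.

The compounds shown leave open at what concentration any of them becomes cytotoxic, and whether the substituent on this aromatic carbon matters at all.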